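The compounds below may be only part of what the source reports. "The series", "measured", "known", "first", "only" and "open" are said of these compounds alone.

Compound 1 `O=C(NCCCCCCCCn1ccnc1)c1cc2cc(Cl)ccc2[nH]1` joins an amide through a saturated chain to an imidazole ring. For the measured compounds named here, in an assay on isolated protein for inhibition of Thromboxane-A synthase (Rattus norvegicus) (a higher number here means a weaker inhibitor, a lower number a stronger inhibitor), compound 1 gives 27 nM, the lowest of the three numbers measured so far and well clear of the other two. Compound 2 `O=C(NCCCCCn1ccnc1)c1ccc(Cl)s1` has a different core and a shorter chain; in this assay compound 2 gives 200 nM. Compound 3 `O=C(NCCCCn1ccnc1)c1ccc(Cl)s1` trims that chain a little further, and in this assay compound 3 gives 200 nM. Compound 4 `O=C(NCCCCCn1ccnc1)c1cc2cc(Cl)ccc2[nH]1` has not yet been measured; it keeps the core of compound 1, and the change is 1H-imidazol-1-yl in place of 3-(1H-imidazol-1-yl)propyl on a saturated chain carbon, five bonds along the chain from an amide-type nitrogen. Going by the values given here, the one measured step of the same kind is no change at the digits printed from compound 2 to compound 3 (within the scatter), where taking a short piece out of the chain left the number where it was. The change from compound 1 to compound 4 removes a longer piece of chain than that step covered, so a modest weakening is expected rather than none, with wide uncertainty around it. The expected step is a 2.2-fold higher number from compound 1 to compound 4 (0.35 log units; beyond the scatter). Compound 4 is therefore estimated at 60 nM, within a range from 20 nM to 200 nM.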

Compound 4, half-maximal inhibitory concentration: 7 nM
For compound 4 the middle estimate is 8.6-fold (0.93 log units) above the measured one; the measured number lies below the stated range.
By their numbers in this assay, from the lowest: compound 4; then compound 1; then compounds 2 and 3 (each within the scatter of the next).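

On the core of compound 1, taking out part of the saturated chain does not cost activity in this assay: replacing 3-(1H-imidazol-1-yl)propyl with 1H-imidazol-1-yl gives a 3.9-fold lower number from compound 1 to compound 4 (0.59 log units; beyond the scatter), so the shorter chain gives the stronger inhibitor of this pair. The earlier shortening, on a different core and by a smaller piece, gave no change at the digits printed from compound 2 to compound 3 (within the scatter), so that step alone gave no sign that chain length could matter this much, and the new step shows that the imidazole need not sit far out on a long chain for a low number on this core. No measurement here accounts for the gain.

With only two chain lengths on this core, the compounds shown leave open whether the number would keep falling with a still shorter chain or whether some chain length between those of compound 1 and compound 4 would do better still. They also leave open whether a pyridine ring could take the place of the imidazole at the end of the chain and keep the number this low.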